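The source may report more compounds than this note shows. Statements on the series, on what has been measured and on what is new or still open speak of the compounds shown alone.

Compound 1 `COc1cc(N)c(Cl)cc1C(=O)CCC1CCN(CCNS(=O)(=O)c2cc(Br)ccc2Br)CC1` in an assay on HEK293 cells for displacement of a labelled ligand from 5-hydroxytryptamine receptor 6 (Homo sapiens), with a stated time of 60 min, tested at 1 uM, in the presence of a further agent that is not named here; on this read-out lower numbers stand for a weaker effect and higher numbers for a stronger effect at the one concentration tested: 52%
Compound 2 `COc1ccc(S(=O)(=O)NCCN2CCC(CCC(=O)c3cc(Cl)c(N)cc3OC)CC2)cc1Cl` in this assay: 85%

Compound 2 stands highest of the two numbers; its nearest neighbour is compound 1, and the step of a number 33 percentage points higher from compound 1 to compound 2 (beyond the scatter) lies beyond the scatter. Compound 3 `COc1cc(N)c(Cl)cc1C(=O)CCC1CCN(CCNS(=O)(=O)c2ccc3c(c2)NC(=O)CO3)CC1` differs from compound 2 by a group of 11 heavy atoms (8 carbon, 1 nitrogen, 2 oxygen; one six-membered non-aromatic ring with 2 hetero atoms, one six-membered aromatic ring of carbon only) in place of a group of 9 heavy atoms (7 carbon, 1 oxygen, 1 chlorine; one six-membered aromatic ring of carbon only), on a sulfonyl sulfur. Among the compounds with values here, the only measured step that bears on this change is a number 33 percentage points higher from compound 1 to compound 2 (beyond the scatter), which shows that the group on the sulfonyl sulfur can move the read-out strongly; no measured compound carries the entering group. Compound 3 is therefore expected to fall, with the step of a number 20 percentage points lower from compound 2 to compound 3 (beyond the scatter). The estimate for compound 3 is 65%, with a range from 35% to 90%.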

Compound 3, a percentage reported as inhibition, at one concentration (the size of the read-out at that concentration, not a potency): 40%
Compound 3: the middle estimate sits 25 percentage points above what was measured; the range from low to high includes it.
By their numbers in this assay, from the lowest: compound 3; then compound 1; then compound 2.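

In this assay, the group with the six-membered non-aromatic ring gives a number 45 percentage points lower from compound 2 to compound 3 (beyond the scatter) and also a number 12 percentage points lower from compound 1 to compound 3 (beyond the scatter) on the same sulfonyl sulfur. The sulfonyl sulfur position therefore spans a wider range than the two aryl groups showed, and this larger group with a hydrogen-bond donor reads lowest of the three. No measurement here accounts for this fall. The compounds leave open whether the lower number goes with the second ring, the amide hydrogen or the ring oxygens. As far as these compounds go, what a plain phenyl group would give on this sulfonyl sulfur also stays open.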